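The source may report more compounds than this note shows. Statements on the series, on what has been measured and on what is new or still open speak of the compounds shown alone.

For the measured compounds named here, in a functional assay on RAW264.7 cells (Mus musculus) for inhibition, read by Griess assay, with stated times of 1 h and 24 h (a higher number here means a weaker inhibitor, a lower number a stronger inhibitor), two compounds have numbers so far. Compound 1 (`CCC(OC(CO)Cc1ccc(O)c(OC)c1)C(OC)c1cc(OC)c(O)c(OC)c1`) gives 41900 nM, and compound 2 (`COc1cc([C@H]2Oc3c(OC)cc(/C=C/CO)cc3[C@@H]2CO)cc(OC)c1O`) gives 11700 nM. Compound 2 therefore holds the lower of the two numbers, by a gap beyond the usual scatter, and is the stronger inhibitor of this pair. Compound 3 (`COc1cc([C@@H]2Oc3c(OC)cc(/C=C/CO)cc3[C@H]2CO)cc(OC)c1O`) has not yet been measured. Set against compound 2, its change is this: the two compounds have the same atoms and bonds and differ only in configuration as drawn: 2 of 3 stereo elements differ; a stereocentre at a saturated ring carbon is drawn S in compound 2 and R in compound 3; a stereocentre at a saturated ring carbon is drawn R in compound 2 and S in compound 3. Nothing leaves and nothing enters, and the two compounds have the same atoms and bonds. Going by the values given here, no measured pair here shows what such a change in configuration does to the number, so only a small shift towards a higher number is expected. The expected step, a 1.3-fold higher number from compound 2 to compound 3 (0.11 log units; within the scatter), stays within the scatter. For compound 3 the estimated value is 15000 nM, with an expected range from 6000 nM to 40000 nM.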

Compound 3, half-maximal inhibitory concentration: 12800 nM
Compound 3: middle estimate off by 1.2-fold (0.07 log units), on the high side, and the stated range covers the measured number.
By their numbers in this assay, from the lowest: compounds 2 and 3 (each within the scatter of the next); then compound 1.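

Swapping the drawn configuration at both stereocentres at saturated ring carbons gives a 1.1-fold higher number from compound 2 to compound 3 (0.04 log units; within the scatter) in this assay, the first measured reading of a change of this kind. At this level of measurement, the number does not separate these two drawn configurations, so compound 2 and compound 3 stand together in this assay. The step can be read as one of configuration alone, with no change of group to confound it: the fact that compounds 2 and 3 differ only in the configuration as drawn.

As far as these compounds go, both stereocentres change together in this pair, so what a change at only one of them would do to the number remains open. Also open, from the compounds shown here alone, is whether a carboxylic acid or an amine on the shared core would shift the number where this change in configuration leaves it within the scatter.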